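The compounds below may be only part of what the source reports. "The series", "measured", "known", "first", "only" and "open" are said of these compounds alone.

Compound 1 `Cc1cc(NC(=O)Cn2nnc(-c3ccccn3)n2)n(C2CCCCC2)n1`: 81%
Compound 2 `Cc1cc(NC(=O)Cn2nnc(-c3cc(Cl)cc(Cl)c3)n2)n(C2CCCCC2)n1`: 82%

Both compounds share one core and differ only in the aromatic group carried on the five-membered ring with four nitrogen atoms. In an assay on HEK293 cells for activation of Kir3.1/Kir3.2 (Homo sapiens), read by thallium flux (on this read-out higher numbers stand for larger maximal responses and lower numbers for smaller maximal responses), compound 1 gives 81%, and compound 2 gives 82%. For the measured compounds named here, compound 2 holds the higher of the two numbers, yet its only neighbour is compound 1, and the step of a number 1 percentage points higher from compound 1 to compound 2 (within the scatter) lies within the scatter, so the two values cannot be told apart.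

Compound 3 `Cc1cc(NC(=O)Cn2nnc(-c3ccc(F)cc3)n2)n(C2CCCCC2)n1` has not been measured yet. It arises from compound 2 by the change (4-fluorophenyl in place of 3,5-dichlorophenyl on an aromatic carbon). Going by the values given here, the one measured step that bears on this, a number 1 percentage points higher from compound 1 to compound 2 (within the scatter), also exchanged the aromatic group at the same place and left the maximal response essentially unchanged. For compound 3 the expected step is therefore a number 4 percentage points lower from compound 2 to compound 3 (within the scatter), that is, nothing beyond the scatter. Compound 3 is estimated at 78%, with a range from 55% to 98%.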

Compound 3, largest response reached (Emax), in percent of the reference or control that the assay uses: 92%
Beside the measured number, compound 3's estimate is 14 percentage points below it, within the range that was stated.
By their numbers in this assay, from the lowest: compounds 1, 2 and 3 (each within the scatter of the next, the first and the last beyond it).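

In this assay, for the compounds shown here, the group on the shared core's five-membered ring with four nitrogen atoms can now be seen to matter: replacing pyridin-2-yl with 4-fluorophenyl gives a number 11 percentage points higher from compound 1 to compound 3 (beyond the scatter), the first step at this place to pass the scatter, though only modestly. Replacing 3,5-dichlorophenyl with 4-fluorophenyl gives a number 10 percentage points higher from compound 2 to compound 3 (within the scatter), so these two groups cannot be separated, just as 3,5-dichlorophenyl and pyridin-2-yl could not, and the three groups fall into no clean order. Nothing available explains the one difference that passes the scatter.

The compounds shown leave open how plain phenyl, or a phenyl carrying a methoxy group or an amine, would behave at this place. They also leave open whether an aromatic ring is needed here at all, or whether a saturated cyclohexyl group could take its place.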